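This account rests on a few compounds, and the source may have more. Where it says the series, first, only, none or still open, it means among the compounds named here.

Measured in a functional assay on DU-145 cells (Homo sapiens) for inhibition, read by trypan blue exclusion, with a stated time of 72 h; on this read-out lower numbers stand for stronger inhibition and higher numbers for weaker inhibition:
compound 1 `COC(=O)Cn1c(=O)c(S(=O)(=O)c2ccc(F)cc2F)cc2cnc(Nc3ccc4[nH]ccc4c3)nc21`: 10000 nM
compound 2 `Cn1c(=O)c(S(=O)(=O)c2ccc(C(=O)O)cc2)cc2cnc(Nc3ccc4[nH]ccc4c3)nc21`: 10000 nM
compound 3 `CCCn1c(=O)c(S(=O)(=O)c2ccc(F)cc2F)cc2cnc(Nc3ccc4[nH]ccc4c3)nc21`: 1000 nM

Compound 2 is level with compound 1, and these two share the highest number of the three. Compound 3 has the lowest number, so compound 2 stands at the weak end of this small set.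

The next compound, compound 4 `Cn1c(=O)c(S(=O)(=O)c2ccc(Cl)cc2)cc2cnc(Nc3ccc4[nH]ccc4c3)nc21`, has not yet been measured. It replaces the carboxy group of compound 2 with chloro, on an aromatic carbon of a six-membered aromatic ring of carbon only, para to a large group: chloro in place of carboxy on an aromatic carbon. In short, 4-carboxyphenyl becomes 4-chlorophenyl.

Among the measured compounds shown here, only one measured step offers any guidance: a 10-fold lower number from compound 1 to compound 3 (1.00 log units; beyond the scatter). That step exchanges methoxycarbonyl for ethyl on a saturated chain carbon bound to an aromatic nitrogen, so it is a different change in a different place. For the measured compounds named here, no measured step tests the change made here, and the guidance is therefore weak. Still, it shows that one exchange in this series moved the number well beyond the scatter, and in the downward direction.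

A moderate move towards stronger inhibition is therefore expected, with the expected size being a 4.0-fold lower number from compound 2 to compound 4 (0.60 log units; beyond the scatter). No change at all would not be a surprise. For compound 4 the estimated value is 2500 nM, with an expected range from 500 nM to 10000 nM.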

Compound 4, half-maximal inhibitory concentration: 250 nM
For compound 4 the middle estimate is 10-fold (1.00 log units) above the measured one, outside the stated range (below it).
By their numbers in this assay, from the lowest: compound 4; then compound 3; then compounds 1 and 2 (each within the scatter of the next).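

In this assay, among the compounds shown here, the exchange of carboxy for chloro, on an aromatic carbon of a six-membered aromatic ring of carbon only, para to a large group, gives a 40-fold lower number from compound 2 to compound 4 (1.60 log units; beyond the scatter) and is the first measured change at this place. The earlier single step, a 10-fold lower number from compound 1 to compound 3 (1.00 log units; beyond the scatter), concerned a chain on an aromatic nitrogen, so this result adds a second place in the series where one exchange moves the number beyond the scatter; here, a group of three heavy atoms with a hydrogen-bond donor and acceptor gives way to a single chlorine atom with neither. Nothing available here explains why the number fell so far.

A single pair cannot separate the effect of adding chloro from that of removing carboxy, and a methyl group, a methoxy group, bromo or an amine at this same place would help to tell the two apart. From the compounds shown here alone, it also remains open whether the same exchange would give a step of similar size in compounds carrying a longer chain on the aromatic nitrogen, rather than the methyl group shared by compound 2 and compound 4.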